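Working notes: amide-to-sulfonyl step, compound 3 pending

The source may hold more compounds than are shown below. What is called first, only, known or untested is meant among the compounds shown, and "the series" means these compounds.

Measured so far:
compound 1, `O=C(Nc1cccc(/C=C/C(=O)c2nc3ccccc3[nH]2)c1)c1cccc(Cl)c1`: 1120 nM
compound 2, `Cc1ccc(C(=O)Nc2cccc(/C=C/C(=O)c3nc4ccccc4[nH]3)c2)cc1`: 1660 nM

In a functional assay on HCT-116 cells (Homo sapiens) for antiproliferative activity, read by MTT assay, with a stated time of 48 h (a lower number here means a stronger inhibitor, a higher number a weaker inhibitor), compound 1 gives 1120 nM and compound 2 gives 1660 nM. Within the data shown here, the single measured step, a 1.5-fold higher number from compound 1 to compound 2 (0.17 log units; within the scatter), is the only step so far. Compound 2 therefore carries the higher of the two numbers shown, but its gap to compound 1 is within the scatter, so the two compounds cannot be ordered.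

Compound 3, `O=C(/C=C/c1cccc(NS(=O)(=O)c2ccc(Cl)cc2)c1)c1nc2ccccc2[nH]1`, differs from compound 2 as follows: (4-chlorophenyl)sulfonyl in place of (4-methylphenyl)carbonyl on a nitrogen on an aromatic ring. Among the measured compounds shown here, the measured step exchanged one aromatic ring for another while the carbonyl stayed in place; the change to compound 3 replaces the carbonyl itself by a sulfonyl and also changes the ring, so no measured step bears on it directly. For the measured compounds named here, the one guide is that the ring exchange alone moved the number little. For compound 3 the expected step is a 1.1-fold lower number from compound 2 to compound 3 (0.04 log units; within the scatter), held close to no change but with a wide range owing to the untested sulfonyl. Compound 3 is estimated at 1500 nM, with a range from 500 nM to 5000 nM.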

Compound 3, half-maximal inhibitory concentration: 1960 nM
The estimate for compound 3 lay 1.3-fold (0.12 log units) below the measured number, within the range that was stated.
By their numbers in this assay, from the lowest: compounds 1, 2 and 3 (each within the scatter of the next).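

In this assay the nitrogen on the aromatic ring now carries a sulfonyl as well as a carbonyl, and the exchange gives a 1.2-fold higher number from compound 2 to compound 3 (0.07 log units; within the scatter) with (4-chlorophenyl)sulfonyl in place of (4-methylphenyl)carbonyl, and a 1.8-fold higher number from compound 1 to compound 3 (0.24 log units; within the scatter) with (4-chlorophenyl)sulfonyl in place of (3-chlorophenyl)carbonyl. The earlier pair changed only the ring on the carbonyl, whereas these two steps change the carbonyl itself, and neither separates compound 3 from the two carbonyl compounds, so the three groups at this place cannot be ordered. Nothing available on these compounds offers an explanation for this outcome.

From the compounds shown here alone, both steps change the ring substituent together with the carbonyl-to-sulfonyl exchange, so the contribution of the sulfonyl alone remains open until it is compared with the ring held the same, as in a (4-methylphenyl)sulfonyl or (4-chlorophenyl)carbonyl group on this nitrogen. Also open is how the series responds to a group of another kind at this place, such as a free amine or an acetyl, since all three groups shown here join an aromatic ring to the nitrogen through a carbonyl or a sulfonyl.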